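Shifting a methoxy group on the amide-bound phenyl ring

The source may hold more compounds than are shown below. What is called first, only, known or untested is meant among the compounds shown, and "the series" means these compounds.

a functional assay on PC-3 cells (Homo sapiens) for inhibition, read by sulforhodamine B assay, with a stated time of 48 h (a higher number here means a weaker inhibitor of growth, a lower number a stronger inhibitor of growth), has so far been run on two compounds that share a common core. Compound 1 `O=C(Nc1ccc(O)cc1)C1NCCc2ccccc21` gives 4250 nM in this assay. Compound 2 `COc1ccc(NC(=O)C2c3ccccc3CCN2C(=O)c2ccc(Cl)cc2)cc1` gives 3480 nM in this assay. Among these two numbers, compound 2 sits at the low end, but its gap to compound 1 lies within the usual scatter of such measurements, so the two readings cannot be told apart. Compound 3 `COc1ccccc1NC(=O)C1c2ccccc2CCN1C(=O)c1ccc(Cl)cc1` has not yet been measured in this assay. It is built from the same atoms as compound 2, joined differently: 2-methoxyphenyl in place of 4-methoxyphenyl on an amide-type nitrogen. Among the compounds with values here, no measured pair in this small set shows what such a change does, so the data give no pull in either direction. The step expected in this assay is a 1.0-fold higher number from compound 2 to compound 3 (0.00 log units; within the scatter), that is, none beyond the scatter. In this assay compound 3 is expected to give about 3500 nM, with a range from 1500 nM to 9000 nM.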

Compound 3, concentration for 50% growth inhibition: 2010 nM
The estimate for compound 3 lay 1.7-fold (0.24 log units) above the measured number; the range from low to high includes it.
By their numbers in this assay, from the lowest: compounds 3, 2 and 1 (each within the scatter of the next, the first and the last beyond it).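

Within the data shown here, the first pair in this set that differs in one place has 2-methoxyphenyl in place of 4-methoxyphenyl on an amide-type nitrogen, and in this assay it reads as a 1.7-fold lower number from compound 2 to compound 3 (0.24 log units; within the scatter). The two placements of the methoxy group therefore cannot be told apart, so this pair gives no sign that the choice between them matters for growth inhibition of these cells, although one pair cannot establish a general rule. Nothing measured here bears on why the two readings cannot be separated.

The compounds shown leave open whether a different group on this phenyl ring, such as an amine or a carboxylic acid in place of the methoxy group, would give a step beyond the scatter. Among these compounds, they also cannot show what the chlorine-bearing benzoyl group contributes, since compound 1 differs from compound 2 and compound 3 in more than one place, and a version of compound 2 with only that group removed would be needed to read its contribution.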